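Acetyl to 2-carboxyethyl on the chain of compound 3

A few compounds are considered here, and "the series" means these few. Any claim that something is new, unique, unknown or untested is made for them only; others in the source may bear on it.

Three compounds of the series have numbers in an assay on isolated protein (Oryctolagus cuniculus) with Thromboxane-A synthase (Homo sapiens) as the target, tested at 1 uM; on this read-out higher numbers stand for more inhibition at the one concentration tested (going by the name of the read-out) and lower numbers for less inhibition. Compound 1 `Cn1nc(-c2cccnc2)c2ccccc2c1=O` gives 63% in this assay, compound 2 `CCCCn1nc(-c2cccnc2)c2ccccc2c1=O` gives 91% and compound 3 `CC(=O)Cn1nc(-c2cccnc2)c2ccccc2c1=O` gives 13%. Compound 3 thus holds the lowest number of the three: the step of a number 50 percentage points lower from compound 1 to compound 3 (beyond the scatter) and the step of a number 78 percentage points lower from compound 2 to compound 3 (beyond the scatter) are both beyond the scatter, while the step of a number 28 percentage points higher from compound 1 to compound 2 (beyond the scatter) runs the other way.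

Compound 4 `O=C(O)CCCn1nc(-c2cccnc2)c2ccccc2c1=O` is not yet measured. It differs from compound 3 by 2-carboxyethyl in place of acetyl on a saturated chain carbon bound to an aromatic nitrogen.

Going by the values given here, two measured steps bear on this change. Replacing hydrogen by acetyl at the same place cost much, as did replacing propyl by acetyl, so the acetyl group that now leaves is associated with the low number of compound 3. Lengthening the chain, on the other hand, raised the number from compound 1 to compound 2. The entering 2-carboxyethyl is a longer chain but still carries a carbonyl, so a partial recovery rather than a full return to the number of compound 2 is expected. The estimated step is a number 42 percentage points higher from compound 3 to compound 4 (beyond the scatter), upward and beyond the scatter.

For compound 4 the estimate in this assay is 55%, expected between 20% and 88%.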

Compound 4, a percentage reported as inhibition, at one concentration (the size of the read-out at that concentration, not a potency): 73%
For compound 4 the middle estimate is 18 percentage points below the measured one; the measured number falls inside the stated range.
By their numbers in this assay, from the lowest: compound 3; then compounds 1 and 4 (each within the scatter of the next); then compound 2.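

In this assay, the step of a number 60 percentage points higher from compound 3 to compound 4 (beyond the scatter) shows that a carbonyl in the substituent on the saturated chain carbon bound to an aromatic nitrogen does not by itself go with a low number, since compound 4 also carries one. The step of a number 10 percentage points higher from compound 1 to compound 4 (within the scatter) shows that 2-carboxyethyl in place of hydrogen does not separate these two compounds in this assay, so the longer chain bearing carboxy does not reproduce the gain seen with propyl. The step of a number 18 percentage points lower from compound 2 to compound 4 (beyond the scatter) shows that carboxy in place of methyl, on a saturated chain carbon three bonds along the chain from an aromatic nitrogen, costs a modest amount, a much smaller step than a number 78 percentage points lower from compound 2 to compound 3 (beyond the scatter).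

No measurement at hand gives a reason for the wide gap between the acetyl and 2-carboxyethyl compounds. As far as these compounds go, whether an amine, an amide or a methyl ester in place of carboxy, or a longer chain carrying the carboxy, would hold the number of compound 4 or come closer to that of compound 2 remains open.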